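The source may report more compounds than this note shows. Statements on the series, on what has been measured and on what is new or still open speak of the compounds shown alone.

Compound 1, `CN(C)c1ccc2c(=O)c(C(=O)Nc3cc(F)cc(F)c3)cn(-c3ccc(OCCCCCCC[N+]45CCN(CC4)CC5)cc3Cl)c2n1`, and compound 2, `CN(C)c1ccc2c(=O)c(C(=O)Nc3cc(F)cc(F)c3)cn(-c3ccc(OCCCCCCC[N+]45CCN(CC4)CC5)cc3F)c2n1`, share one core and differ only in the change (fluoro in place of chloro on an aromatic carbon). In an assay on LX2 cells for inhibition of COL1A1 promoter (Homo sapiens), read by a luciferase reporter, with a stated time of 24 h, tested at 50 uM (on this read-out lower numbers stand for a weaker effect and higher numbers for a stronger effect at the one concentration tested), compound 1 gives 80%, while compound 2 gives 42.4% in this assay. The step of a number 37.6 percentage points lower from compound 1 to compound 2 (beyond the scatter) is large and lies beyond the usual scatter.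

Compound 3, `CN(C)c1ccc2c(=O)c(C(=O)Nc3cc(F)cc(F)c3)cn(-c3ccc(OCCCCCCC[N+]4(C)CCCCC4)cc3Cl)c2n1`, carries a different core from compound 1; the difference is a group of 7 heavy atoms (6 carbon, 1 nitrogen; one six-membered non-aromatic ring with 1 hetero atom) in place of a group of 8 heavy atoms (6 carbon, 2 nitrogen; 2 six-membered non-aromatic rings with 2 hetero atoms each), on a saturated chain carbon, seven bonds along the chain from an oxygen on an aromatic ring. In this assay compound 3 is reported as "not active" (no number reported), and no number is given for it.

Compound 4, `CN(C)c1ccc2c(=O)c(C(=O)Nc3cc(F)cc(F)c3)cn(-c3ccc(OCCCCCCC[N+]4(C)CCCCC4)cc3F)c2n1`, has not been measured. It stands to compound 3 as compound 2 stands to compound 1: the difference is fluoro in place of chloro on an aromatic carbon, and since the place of the change is described in the same words for both pairs, it is the same change, made on the core of compound 3 rather than on the core of compound 1.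

In this assay the same change already moved compound 1 to compound 2 by a number 37.6 percentage points lower from compound 1 to compound 2 (beyond the scatter), and compound 3 starts from a point reported as not active. On that basis compound 4 is expected to sit at or near the bottom of the read-out in this assay, and it may well be reported only as not active. The estimate for compound 4 in this assay is 5%, with an expected range from -5% to 25%.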

Compound 4, a percentage reported as inhibition, at one concentration (the size of the read-out at that concentration, not a potency): "not active" (no number reported)
Nothing numeric was reported for compound 4; the estimate stays without a comparison.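

No new step can be read between compound 3 and compound 4: in this assay compound 3 gives "not active" (no number reported) and compound 4 gives "not active" (no number reported) with no number for either. The compounds shown leave open whether fluoro in place of chloro changes the read-out at all on the core of compound 3. No measurement shown here explains these results.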